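Ring Swap on the Thiocarbonyl Carbon

The source may report more compounds than this note shows. Statements on the series, on what has been measured and on what is new or still open speak of the compounds shown alone.

Among the compounds with values here, compound 2 `Cc1cccc(/C(N)=N/NC(=S)N2CCOCC2)n1` gives 43.6% in a functional assay on A-375 cells (Homo sapiens) for cytotoxicity, read by MTT assay, with a stated time of 72 h, tested at 10 uM (on this read-out higher numbers stand for more inhibition of growth at the one concentration tested and lower numbers for less inhibition of growth), and stands second highest of the three numbers measured so far. Within the data shown here, its nearest neighbour is compound 1 `N/C(=N\NC(=S)N1CCOCC1)c1ccccn1`, which in this assay gives 18.3%; the step of a number 25.3 percentage points higher from compound 1 to compound 2 (beyond the scatter) is the only single-point change measured in this set. Compound 3 `Cc1ccnc(/C(N)=N/NC(=S)N2CCCCCC2)c1` gives 70.6% in this assay and lies furthest from compound 2, but it differs from compound 2 in two places at once.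

Compound 4 `Cc1cccc(/C(N)=N/NC(=S)N2CCCC2)n1` differs from compound 2 in one place: pyrrolidin-1-yl in place of morpholin-4-yl on a thiocarbonyl carbon. Among the measured compounds shown here, no measured step isolates this change. The step of a number 25.3 percentage points higher from compound 1 to compound 2 (beyond the scatter) concerns a methyl on the aromatic carbon and says nothing about the ring on the thiocarbonyl carbon. For the measured compounds named here, the only hint is that compound 3, whose ring on that carbon carries no oxygen, shows a higher number than compound 2, though a second change separates them. The direction in this assay is therefore uncertain, with a modest rise judged somewhat more likely than a fall. Compound 4 is expected to give about 55%, within a range from 35% to 75%. This estimate amounts to an expected step of a number 11.4 percentage points higher from compound 2 to compound 4 (beyond the scatter), only just beyond the scatter.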

Compound 4, percent growth inhibition at one concentration: 55.9%
Estimate against measurement, compound 4: 0.9 percentage points below, and the stated range covers the measured number.
By their numbers in this assay, from the lowest: compound 1; then compound 2; then compound 4; then compound 3.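

In this assay, the ring on the thiocarbonyl carbon now has a measured effect of its own: pyrrolidin-1-yl in place of morpholin-4-yl gives a number 12.3 percentage points higher from compound 2 to compound 4 (beyond the scatter). Within the data shown here, until now, the only single-place change was the methyl on an aromatic carbon, which gave a number 25.3 percentage points higher from compound 1 to compound 2 (beyond the scatter), so the ring on the thiocarbonyl carbon is a second place where one change moves the number beyond the scatter, and this step too is modest. No measurement offered here gives a reason for the rise, so the step stands as an observation without an explanation.

The change replaces a six-membered ring bearing oxygen with a five-membered ring without it, so the compounds shown cannot separate ring size from the loss of the oxygen, and compound 3 cannot settle this since it differs from compound 2 and compound 4 in more than one place. Piperidin-1-yl on the same thiocarbonyl carbon, a six-membered ring without oxygen, would bear directly on that question, and an open-chain diethylamino group would show whether a ring is needed there at all.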